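A few compounds are considered here, and "the series" means these few. Any claim that something is new, unique, unknown or untested is made for them only; others in the source may bear on it.

Three compounds on the shared core have numbers in an assay on CHO cells for antagonist activity at transient receptor potential cation channel subfamily V member 1 (Homo sapiens), read by FLIPR; a higher number here means a weaker inhibitor, a lower number a stronger inhibitor. Compound 1 `CC(C(=O)NCc1ccc(C(F)(F)F)cc1SC1CCCC1)c1ccc(NS(C)(=O)=O)c(F)c1` gives 0.3 nM; compound 2 `CC(C(=O)NCc1ccc(C(F)(F)F)cc1SCc1ccco1)c1ccc(NS(C)(=O)=O)c(F)c1` gives 3.2 nM; compound 3 `CC(C(=O)NCc1ccc(C(F)(F)F)cc1Cl)c1ccc(NS(C)(=O)=O)c(F)c1` gives 4 nM, the highest of the three, standing a 1.3-fold higher number from compound 2 to compound 3 (0.10 log units; within the scatter) and a 13-fold higher number from compound 1 to compound 3 (1.12 log units; beyond the scatter). Compound 4 `CC(C(=O)NCc1ccc(C(F)(F)F)cc1C1CCCCC1)c1ccc(NS(C)(=O)=O)c(F)c1` is not yet measured; it differs from compound 3 by cyclohexyl in place of chloro on an aromatic carbon. For the measured compounds named here, the only step that bears on this is the one from compound 1 to compound 3, in which cyclopentylsulfanyl was traded for chloro and the number rose by a large amount. Compound 4 runs that exchange in the opposite sense, so a large drop toward the number of compound 1 is expected, as an expectation only. Compound 4 is therefore estimated at 0.8 nM, within 0.2 nM to 3 nM, a step of a 5.0-fold lower number from compound 3 to compound 4 (0.70 log units; beyond the scatter).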

Compound 4, inhibition constant: 0.6 nM
Compound 4: middle estimate off by 1.3-fold (0.12 log units), on the high side; the range from low to high includes it.
By their numbers in this assay, from the lowest: compounds 1 and 4 (each within the scatter of the next); then compounds 2 and 3 (each within the scatter of the next).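

In this assay, this position does not need a sulfur link: cyclohexyl in place of chloro gives a 6.7-fold lower number from compound 3 to compound 4 (0.82 log units; beyond the scatter), and exchanging cyclopentylsulfanyl for cyclohexyl gives a 2.0-fold higher number from compound 1 to compound 4 (0.30 log units; within the scatter). ((Furan-2-yl)methyl)sulfanyl does not match cyclohexyl, with a 5.3-fold lower number from compound 2 to compound 4 (0.73 log units; beyond the scatter), so a sulfur link alone does not set the number either. No measurement at hand accounts for these steps.

Open, from the compounds shown here alone, is whether an amine such as piperidine, a flat phenyl ring or a short open chain such as isopropyl would hold the number at this position.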